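Leaving 2,4-dimethylphenyl: compound 3 to compound 4

The source may hold more compounds than are shown below. What is called first, only, known or untested is meant among the compounds shown, and "the series" means these compounds.

In a functional assay on Jurkat cells (Homo sapiens) (on this read-out lower numbers stand for stronger inhibition and higher numbers for weaker inhibition), compound 1 `Cc1cccc(CNC(=O)C(=O)N[C@@H](C)C(=O)N[C@@H](CC(=O)O)C(=O)COc2c(F)c(F)cc(F)c2F)c1` gives 127 nM and compound 2 `Cc1cccc(CNC(=O)C(=O)N[C@@H](C)C(=O)N[C@@H](CC(=O)O)C(=O)COc2c(F)c(F)cc(F)c2F)c1C` gives 102 nM, with a 1.2-fold lower number from compound 1 to compound 2 (0.10 log units; within the scatter). Compound 3 `Cc1ccc(CNC(=O)C(=O)N[C@@H](C)C(=O)N[C@@H](CC(=O)O)C(=O)COc2c(F)c(F)cc(F)c2F)c(C)c1` gives > 10000 nM, which is a limit of the assay and not a number. Compound 4 `C[C@H](NC(=O)C(=O)NCc1cc(Cl)ccc1Cl)C(=O)N[C@@H](CC(=O)O)C(=O)COc1c(F)c(F)cc(F)c1F` differs from it as follows: 2,5-dichlorophenyl in place of 2,4-dimethylphenyl on a saturated chain carbon bound to an amide-type nitrogen. The steps bearing on this change are an at least 78-fold higher number from compound 1 to compound 3 (1.89 log units; beyond the scatter) and an at least 98-fold higher number from compound 2 to compound 3 (1.99 log units; beyond the scatter), both large and both ending on the 2,4-dimethylphenyl group, so a large fall in the number is expected on leaving that group. Within the data shown here, no measured compound holds chlorine, so the size stays uncertain. The expected step is an at least 25-fold lower number from compound 3 to compound 4 (1.39 log units; beyond the scatter). For compound 4 the estimate is 400 nM, with an expected range of 50 nM to 6000 nM.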

Compound 4, half-maximal inhibitory concentration: 4.3 nM
For compound 4 the middle estimate is 93-fold (1.97 log units) above the measured one; the whole stated range lies above it.
By their numbers in this assay, from the lowest: compound 4; then compounds 2 and 1 (each within the scatter of the next). At a limit, above all of these: compound 3.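

On the saturated chain carbon bound to an amide-type nitrogen, the aryl group can do more than the methyl-bearing compounds showed: in this assay, 2,5-dichlorophenyl gives a 30-fold lower number from compound 1 to compound 4 (1.47 log units; beyond the scatter) and a 24-fold lower number from compound 2 to compound 4 (1.38 log units; beyond the scatter), both large. The value of compound 3 is a limit, so an at least 2300-fold lower number from compound 3 to compound 4 (3.36 log units; beyond the scatter) has one bound only: the limit of > 10000 nM in this assay, at which 1 of the 4 values shown sits. Compound 4 is the most potent of the four, with its steps to all the others beyond the scatter.

A 2,5-dimethylphenyl or 2,4-dichlorophenyl group would separate the effect of chlorine from that of the substitution pattern. Going by these compounds, how either reads at this place remains open, as does a methoxy group there.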